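Pyrimidine to Pyridine on a Benzothiophene Agonist Series

The source may report more compounds than this note shows. Statements on the series, on what has been measured and on what is new or still open speak of the compounds shown alone.

Of the compounds shown here, two of a shared core have been measured so far. Compound 1 `CC#C[C@@H](Cc1nnn[nH]1)c1ccc(OCc2ccc3scc(-c4cncnc4C)c3c2)cc1` was tested in a functional assay on cells for agonist activity at Free fatty acid receptor 1 (Homo sapiens), read by FLIPR and calcium flux (on this read-out higher numbers stand for an effect only at larger amounts of compound and lower numbers for an effect already at smaller amounts), where compound 1 gives 37 nM. Compound 2 `CC#C[C@@H](Cc1nnn[nH]1)c1ccc(OCc2cc(F)c3scc(-c4ccc(OC)cc4C)c3c2)cc1` carries a different pattern of substituents on the core, and in this assay compound 2 gives 10 nM. Among the two numbers, compound 1 stands highest, and the gap to compound 2 lies beyond the usual scatter.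

Compound 3 `CC#C[C@@H](Cc1nnn[nH]1)c1ccc(OCc2ccc3scc(-c4cccnc4C)c3c2)cc1` is not yet measured. It differs from compound 1 in a single place: 2-methylpyridin-3-yl in place of 4-methylpyrimidin-5-yl on an aromatic carbon. Among the compounds with values here, no step between two measured compounds differing in exactly one place is available to calibrate this change, so the expectation rests on the values of compound 1 and compound 2 alone. Since compound 1 gives 37 nM and a related substitution pattern in compound 2 reaches 10 nM, a modest step toward lower numbers, or none beyond the scatter, is expected. The step of a 1.5-fold lower number from compound 1 to compound 3 (0.17 log units; within the scatter) is therefore estimated to be small. Compound 3 is expected to give about 25 nM in this assay, within a range of 8 nM to 80 nM.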

Compound 3, half-maximal effective concentration: 88 nM
For compound 3 the middle estimate is 3.5-fold (0.55 log units) below the measured one; the measured number lies above the stated range.
By their numbers in this assay, from the lowest: compound 2; then compound 1; then compound 3.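

At this place on the shared core, two ring bonds from the ring sulfur, replacing 4-methylpyrimidin-5-yl with 2-methylpyridin-3-yl gives a 2.4-fold higher number from compound 1 to compound 3 (0.38 log units; beyond the scatter) in this assay. The two groups match in heavy-atom count and ring size, with one ring nitrogen of the leaving group exchanged for carbon and 1 hydrogen-bond acceptor in the entering group where the leaving group has 2, so this position distinguishes between two closely matched methyl-bearing rings, and of this pair the 4-methylpyrimidin-5-yl group gives the lower number. Nothing available explains why the number moves in this direction, and the comparison alone cannot tie the step to any single feature of the exchange.

Compound 2 differs from compound 1 and compound 3 in more than one place, so it leaves open whether the same exchange would give a similar step on its substitution pattern. Also open, on these data alone, is how this position would respond to a ring without the methyl group, or to a pyridine carrying an amine or a carboxylic acid.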